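A few compounds are considered here, and "the series" means these few. Any claim that something is new, unique, unknown or untested is made for them only; others in the source may bear on it.

Among the measured compounds shown here, compound 1 `CC(=O)Nc1cc(-c2ccc(OC[C@@](C)(N)CC(C)C)c(F)c2)ccn1` is the more potent of the two compounds with numbers so far in an assay on isolated protein for inhibition of AP2-associated protein kinase 1 (Homo sapiens), with a stated time of 3 h, in the presence of a further agent that is not named here; a higher number here means a weaker inhibitor, a lower number a stronger inhibitor: compound 1 gives 0.8 nM, whereas compound 2 `COC(=O)Nc1cc(-c2ccc(OC[C@@](C)(N)CC(C)C)cn2)ccn1` gives 23 nM in this assay. Compound 2 differs from compound 1 in two places at once, so its weaker figure cannot be traced to any single change; all that can be said is what the two values show.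

Compound 3 `COC(=O)Nc1cc(-c2ccc(OC[C@@](C)(N)CC(C)C)c(F)c2)ccn1` sits between them structurally. It keeps the ring of compound 1 and changes only the cap on the nitrogen: methoxy in place of methyl on a carbonyl carbon. For the measured compounds named here, the account therefore rests on a single change with no measured pair of its own to lean on. Since compound 2, which carries the same methoxycarbonyl group, gives 23 nM in this assay, a weakening is the more likely direction for compound 3, though a step within the scatter is expected rather than a large one, and the estimated step from compound 1 to compound 3 is a 2.5-fold higher number from compound 1 to compound 3 (0.40 log units; beyond the scatter). Compound 3 is thus expected to give about 2 nM in this assay, within a range from 0.7 nM to 6 nM.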

Compound 3, half-maximal inhibitory concentration: 1.1 nM
Compound 3: the middle estimate sits 1.8-fold (0.26 log units) above what was measured, within the range that was stated.
By their numbers in this assay, from the lowest: compounds 1 and 3 (each within the scatter of the next); then compound 2.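

In this assay methoxy in place of methyl on a carbonyl carbon gives a 1.4-fold higher number from compound 1 to compound 3 (0.14 log units; within the scatter), so at this place the change from acetamido to (methoxycarbonyl)amino is not told apart from no change at all. Compound 1 and compound 2 alone could not show this, but the methoxycarbonyl group by itself does not go with the higher number: compound 3 carries it and gives 1.1 nM in this assay, while compound 2 carries it too and gives 23 nM in the same assay, so the gap between these two lies with the ring, the one place in which they differ. Nothing measured here says why the acetyl and methoxycarbonyl caps read alike.

The compounds shown leave open whether this place accepts caps further from these two, such as an ethoxy group, a dimethylamino group or a cyclopropyl group on the same carbonyl carbon. They also leave open whether acetamido and (methoxycarbonyl)amino would still read alike on the ring of compound 2, which would show whether the cap and the ring act independently.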